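This account rests on a few compounds, and the source may have more. Where it says the series, first, only, none or still open, it means among the compounds named here.

Compound 1 `CCCCCCCCCCCOC(=O)NC(=O)Oc1c(C(C)C)cccc1C(C)C`, compound 2 `CCCCCCCC(C)OC(=O)NC(=O)Oc1c(C(C)C)cccc1C(C)C` and compound 3 `CCCCCCCCC(C)OC(=O)NC(=O)Oc1c(C(C)C)cccc1C(C)C` share one core and differ only in their saturated chain. In an assay on microsomes from intestine for inhibition of acyl-CoA:cholesterol acyltransferase (Oryctolagus cuniculus) (on this read-out lower numbers stand for stronger inhibition and higher numbers for weaker inhibition), compound 1 gives 140 nM, compound 2 gives 97 nM and compound 3 gives 270 nM. Compound 3 thus carries the highest number of the three; its gap to compound 1 lies within the scatter, while a 2.8-fold higher number from compound 2 to compound 3 (0.44 log units; beyond the scatter) lies beyond it. Compound 4 `CCCCCCCCCCC(C)OC(=O)NC(=O)Oc1c(C(C)C)cccc1C(C)C` carries ethyl in place of hydrogen on a saturated chain carbon, nine bonds along the chain from an oxygen next to a carbonyl group. Within the data shown here, the only measured step of a comparable kind, a 2.8-fold higher number from compound 2 to compound 3 (0.44 log units; beyond the scatter), was modest, so in this assay the expected step is a 1.2-fold higher number from compound 3 to compound 4 (0.07 log units; within the scatter), a slight rise at most. Compound 4 is therefore estimated at 320 nM, with a range of 130 nM to 800 nM.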

Compound 4, half-maximal inhibitory concentration: 49 nM
Estimate against measurement, compound 4: 6.5-fold (0.81 log units) above, and the stated range ends above it.
By their numbers in this assay, from the lowest: compounds 4, 2, 1 and 3 (each within the scatter of the next, the first and the last beyond it).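

In this assay, the ethyl change at this place runs against the earlier methyl step, with a 5.5-fold lower number from compound 3 to compound 4 (0.74 log units; beyond the scatter), so the number does not rise steadily as the chain grows. Compound 4 stays within the scatter of compound 2, at a 2.0-fold lower number from compound 2 to compound 4 (0.30 log units; within the scatter), while methyl on the chain carbon bound to the oxygen gives a 2.9-fold lower number from compound 1 to compound 4 (0.46 log units; beyond the scatter). The outcome of a change therefore depends on the chain that carries it: the same change on two cores in this assay, a 2.8-fold higher number (0.44 log units; beyond the scatter) from compound 2 to compound 3 and a 2.9-fold lower number (0.46 log units; beyond the scatter) from compound 1 to compound 4, 8.0-fold (0.90 log units) apart, beyond the scatter of two such steps. From the compounds shown here alone, whether a longer chain would keep the number as low as in compound 4 stays open, as does the effect of an amine or a carboxylic acid at the chain end.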